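The source may report more compounds than this note shows. Statements on the series, on what has been measured and on what is new or still open speak of the compounds shown alone.

Compound 3 `O=C(O)CC/C=C\CO[C@H]1C(OCc2ccc(-c3ccccc3CCO)cc2)CC[C@@H]1N1CCCCCC1` gives 2 nM in a functional assay on blood for antagonist activity at thromboxane A2 receptor (Homo sapiens) (a lower number here means tighter binding, a higher number weaker binding), and this is the lowest of the three numbers measured. Its nearest neighbour is compound 2 `NC(=O)Cc1ccccc1-c1ccc(COC2CC[C@H](N3CCCCCC3)[C@H]2OC/C=C\CCC(=O)O)cc1`, which gives 7.94 nM in this assay; compound 1 `CC(=O)NCc1ccccc1-c1ccc(COC2CC[C@H](N3CCCCCC3)[C@H]2OC/C=C\CCC(=O)O)cc1` gives 25.1 nM. Both steps to compound 3 are beyond the scatter: a 4.0-fold lower number from compound 2 to compound 3 (0.60 log units; beyond the scatter), and a 13-fold lower number from compound 1 to compound 3 (1.10 log units; beyond the scatter). The step of a 3.2-fold lower number from compound 1 to compound 2 (0.50 log units; beyond the scatter) is modest.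

Compound 4 `NC(=O)c1ccccc1-c1ccc(COC2CC[C@H](N3CCCCCC3)[C@H]2OC/C=C\CCC(=O)O)cc1` is not yet measured. It differs from compound 3 by carbamoyl in place of 2-hydroxyethyl on an aromatic carbon. Among the compounds with values here, no measured step covers a group set directly on the aromatic carbon, so the nearest guide is the comparison of carbamoyl with hydroxymethyl on the chain carbon, where a 4.0-fold lower number from compound 2 to compound 3 (0.60 log units; beyond the scatter) went in favour of the hydroxy group by a modest margin. Compound 2 also carries a carbamoyl, at a chain carbon, and gives 7.94 nM. On that basis compound 4 is expected to be weaker than compound 3, with a step of roughly a 3.5-fold higher number from compound 3 to compound 4 (0.54 log units; beyond the scatter), since the exchange of hydroxyl for amide cost a 4.0-fold lower number from compound 2 to compound 3 (0.60 log units; beyond the scatter) before. Compound 4 is therefore estimated at 7 nM in this assay, within a range of 2.5 nM to 20 nM.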

Compound 4, dissociation constant: 15.9 nM
Beside the measured number, compound 4's estimate is 2.3-fold (0.36 log units) below it; the range from low to high includes it.
By their numbers in this assay, from the lowest: compound 3; then compounds 2, 4 and 1 (each within the scatter of the next, the first and the last beyond it).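

In this assay, setting carbamoyl directly on the aromatic carbon, ortho to a large group, in place of 2-hydroxyethyl gives an 8.0-fold higher number from compound 3 to compound 4 (0.90 log units; beyond the scatter) and so extends the earlier picture: compound 3 now stands apart from all three amide-bearing compounds, including the one whose amide has no chain carbon between it and the aromatic carbon. The other two new steps, a 2.0-fold higher number from compound 2 to compound 4 (0.30 log units; within the scatter) and a 1.6-fold lower number from compound 1 to compound 4 (0.20 log units; within the scatter), both lie within the scatter, so compound 4 cannot be separated from either carbamoylmethyl or acetamidomethyl, even though those two groups do differ from each other beyond the scatter. Nothing further is available to explain these differences.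

The compounds shown cannot say whether the standing of compound 3 rests on the hydroxyl or on the chain that carries it. A hydroxymethyl group set directly on the aromatic carbon, a plain ethyl group, a longer chain ending in hydroxyl, or an amine or carboxylic acid at the end of the same chain would each bear on that question.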